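Swapping a Bromo Substituent for Isopropylsulfanyl

This account rests on a few compounds, and the source may have more. Where it says the series, first, only, none or still open, it means among the compounds named here.

Three acylguanidine compounds have been measured in a functional assay for inhibition of sodium/hydrogen exchanger (Oryctolagus cuniculus); a higher number here means a weaker inhibitor, a lower number a stronger inhibitor. Compound 1, `Cc1cc(Br)c(S(C)(=O)=O)cc1C(=O)N=C(N)N`, gives 12 nM, the lowest number of the three. Compound 2, `Cc1c(C(=O)N=C(N)N)cc(S(C)(=O)=O)c(Cl)c1Cl`, gives 29 nM, a value beyond the scatter above compound 1. Compound 3, `Cc1ccc(-c2ccc(C(=O)N=C(N)N)cc2S(C)(=O)=O)cc1`, gives 100 nM, the highest of the set and also beyond the scatter relative to compound 1. Among the three, compound 1 therefore stands as the strongest inhibitor in this assay.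

Compound 4, `Cc1cc(SC(C)C)c(S(C)(=O)=O)cc1C(=O)N=C(N)N`, has not been measured. It differs from compound 1 in one place: isopropylsulfanyl in place of bromo on an aromatic carbon. Going by the values given here, no pair of measured compounds differing only in this way exists, so no measured step can guide the expectation directly.

The change keeps the acylguanidine, the methyl group and the methylsulfonyl group untouched, so a result near that of compound 1 is expected. The expected step of a 1.3-fold higher number from compound 1 to compound 4 (0.10 log units; within the scatter) is small, within the usual scatter, with no clear direction. Compound 4 is expected to give 15 nM, with a range from 5 nM to 50 nM.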

Compound 4, half-maximal inhibitory concentration: 12 nM
Compound 4: middle estimate off by 1.3-fold (0.10 log units), on the high side; the measured number falls inside the stated range.
By their numbers in this assay, from the lowest: compounds 1 and 4 (each within the scatter of the next); then compound 2; then compound 3.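

In this assay, replacing bromo with isopropylsulfanyl on the aromatic carbon ortho to a methylsulfonyl group brings 4 heavy atoms where there was 1, and the outcome is no change at the digits printed from compound 1 to compound 4 (within the scatter) despite that growth in size. Going by these compounds alone, this is the first pair here that differs in one place only, and it shows that bromine itself is not required at this position for a number this low. Nothing available explains why the two groups give matching numbers.

One replacement cannot show how far this tolerance extends: an amine, a carboxylic acid or a longer chain such as hexylsulfanyl could give a very different number here. From the compounds shown here alone, it also remains open whether isopropylsulfanyl would be matched in the same way by a smaller sulfur group such as methylsulfanyl.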